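Removing a trifluoromethyl from the amide phenyl of compound 1

This account rests on a few compounds, and the source may have more. Where it says the series, first, only, none or still open, it means among the compounds named here.

Measured so far:
- compound 1 `COc1cc(-c2nn(-c3cccc(NC(=O)c4cccc(C(F)(F)F)c4)c3)cc2-c2ccncc2)ccc1Cl`: > 50000 nM
- compound 2 `COc1cc(-c2nn(-c3cccc(NC(=O)Nc4ccc(Cl)c(Cl)c4)c3)cc2-c2ccncc2)ccc1Cl`: 3700 nM
- compound 3 `O=C(Nc1cccc(-n2cc(-c3ccncc3)c(-c3ccc(Cl)c(O)c3)n2)c1)Nc1cc(C(F)(F)F)cc(C(F)(F)F)c1`: 4420 nM

In a functional assay on CAKI-1 cells (Homo sapiens) for inhibition, read by sulforhodamine B assay, with a stated time of 48 h (a higher number here means a weaker inhibitor of growth, a lower number a stronger inhibitor of growth), compound 1 gives only a limit, > 50000 nM, and not a number. Among the three measured compounds, compound 1 is the one sitting at that limit, (the limit of > 50000 nM in this assay, at which 1 of the 3 values shown sits). Compound 2 gives 3700 nM in this assay, and compound 3 gives 4420 nM.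

Compound 4 `COc1cc(-c2nn(-c3cccc(NC(=O)c4ccccc4)c3)cc2-c2ccncc2)ccc1Cl` has not yet been measured. It differs from compound 1 in one place: hydrogen in place of trifluoromethyl on an aromatic carbon, so that the 3-(trifluoromethyl)phenyl on the carbonyl carbon becomes a plain phenyl.

Among the measured compounds shown here, only one step between measured compounds exists, an at least 13-fold lower number from compound 1 to compound 2 (1.13 log units; beyond the scatter), and it changes the group on the carbonyl carbon to (3,4-dichlorophenyl)amino, a different change from the one that leads to compound 4. For the measured compounds named here, no measured step shows what removing the trifluoromethyl alone does, and because compound 1 sits at the limit (the limit of > 50000 nM in this assay, at which 1 of the 3 values shown sits), a step away from it cannot be sized well. The expected result in this assay is therefore a step of uncertain size and direction, an at least 1.2-fold lower number from compound 1 to compound 4 (0.09 log units; that floor lies within the scatter), with the limit itself a likely outcome. For compound 4 the estimate is 40000 nM, within the range 8000 nM to 200000 nM.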

Compound 4, concentration for total growth inhibition: > 100000 nM
Compound 4: only a limit was reported (the forecaster's own chance of this, stated with the estimate: 55%); at least 2.5-fold (0.39 log units) between middle value and limit.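

In this assay compound 4 gives only a limit and not a number, so the plain phenyl on the carbonyl carbon leaves this compound without a measured value: the limit of > 100000 nM in this assay, at which 1 of the 4 values shown sits.
Compound 1 gives a limit as well, so the step that removes the trifluoromethyl cannot be read, and these data do not show whether that group helps, harms or does nothing here: the limit of > 50000 nM in this assay, at which 1 of the 4 values shown sits.
The clearer news comes from the other side of the carbonyl, where placing phenyl in position of (3,4-dichlorophenyl)amino gives an at least 27-fold higher number from compound 2 to compound 4 (1.43 log units; beyond the scatter), a large step beyond the scatter that matches an at least 13-fold lower number from compound 1 to compound 2 (1.13 log units; beyond the scatter) and so shows, across these three compounds, that the group on the carbonyl carbon matters more than the trifluoromethyl can be shown to.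

Still open, going by these compounds, is whether the amino link or the two chlorines carry that difference, a question that a plain phenylamino on the carbonyl carbon would help to settle. Also open, on these data alone, is whether any group in place of the trifluoromethyl, such as an amine or a carboxylic acid, would bring the amide compounds into the range where a number can be read.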